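Returning to a Sulfonyl Group on the Ring Nitrogen

The source may hold more compounds than are shown below. What is called first, only, known or untested is meant among the compounds shown, and "the series" means these compounds.

Of the compounds shown here, three sharing one core have been measured in a functional assay on Jurkat cells (Homo sapiens) for antiproliferative activity, read by MTT assay and trypan blue exclusion, with a stated time of 72 h; on this read-out lower numbers stand for stronger inhibition and higher numbers for weaker inhibition. Compound 1 `COC(=O)c1ccc(C2SCC(=O)N2c2ccc(N3CCN(S(=O)(=O)c4ccccc4)CC3)cn2)c(OC)c1` carries a phenylsulfonyl group on the ring nitrogen and gives 52900 nM. Compound 2 `COC(=O)c1ccc(C2SCC(=O)N2c2ccc(N3CCN(Cc4cccc([N+](=O)[O-])c4)CC3)cn2)c(OC)c1` carries a 3-nitrobenzyl group there and gives 37400 nM; the step of a 1.4-fold lower number from compound 1 to compound 2 (0.15 log units; within the scatter) lies within the scatter. Compound 3 `COC(=O)c1ccc(C2SCC(=O)N2c2ccc(N3CCN(Cc4cccc(C)c4)CC3)cn2)c(OC)c1` carries a 3-methylbenzyl group, and in this assay compound 3 gives only a limit, > 100000 nM, at the limit of > 100000 nM in this assay, at which 1 of the 3 values shown sits. Compound 3 thus stands at the weak end of what is shown: the step of an at least 1.8-fold higher number from compound 1 to compound 3 (0.27 log units; that floor lies within the scatter) has a floor inside the scatter, while the step of an at least 2.6-fold higher number from compound 2 to compound 3 (0.42 log units; beyond the scatter) is beyond it.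

Compound 4 `COC(=O)c1ccc(C2SCC(=O)N2c2ccc(N3CCN(S(=O)(=O)c4ccc(F)cc4)CC3)cn2)c(OC)c1` differs from compound 3 in one place: (4-fluorophenyl)sulfonyl in place of 3-methylbenzyl on an amine nitrogen in a ring. Going by the values given here, the measured step that bears on this is the one from compound 1 to compound 3, which in the reverse direction trades a 3-methylbenzyl group for a phenylsulfonyl group and reaches a number like that of compound 1, 52900 nM. A sulfonyl group entering again is therefore expected to bring compound 4 back near compound 1, a modest lowering at most. Compound 4 is expected to give 55000 nM, within 25000 nM to 120000 nM. The estimated step of an at least 1.8-fold lower number from compound 3 to compound 4 (0.25 log units; that floor lies within the scatter) is expected to be small, given that compound 1 gives 52900 nM.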

Compound 4, half-maximal inhibitory concentration: 78300 nM
Estimate against measurement, compound 4: 1.4-fold (0.15 log units) below; low and high end bracket the measured number.
By their numbers in this assay, from the lowest: compounds 2, 1 and 4 (each within the scatter of the next, the first and the last beyond it). At a limit, above all of these: compound 3.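

In this assay, fluoro in place of hydrogen on an aromatic carbon of the phenylsulfonyl group gives a step that stays within the scatter: a 1.5-fold higher number from compound 1 to compound 4 (0.17 log units; within the scatter). Against the 3-nitrobenzyl group, however, the (4-fluorophenyl)sulfonyl group gives a step beyond the scatter, a 2.1-fold higher number from compound 2 to compound 4 (0.32 log units; beyond the scatter), a separation that the phenylsulfonyl group of compound 1 did not show against that same benzyl group. Compound 3 remains at a limit, so its step gives only a floor, an at least 1.2-fold lower number from compound 3 to compound 4 (0.10 log units; that floor lies within the scatter), and this floor does not separate the 3-methylbenzyl group from the (4-fluorophenyl)sulfonyl group: the limit of > 100000 nM in this assay, at which 1 of the 4 values shown sits.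

The compounds shown carry only sulfonyl and benzyl groups on this ring nitrogen, so it remains open whether an acetyl group, a benzoyl group or a plain alkyl chain there would move the number beyond the scatter of these values. As far as these compounds go, it also remains open whether a chloro or methoxy group in the place of the fluoro would stay within the scatter of compound 1.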